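Para-methyl in place of para-fluoro on the sulfonyl aryl

The compounds below may be only part of what the source reports. "The series", "measured", "known", "first", "only" and "open" are said of these compounds alone.

Compound 1 `CC1CCN(c2c(S(=O)(=O)c3ccc(Cl)c(Cl)c3)cnc3cc(F)ccc23)CC1`: 94%
Compound 2 `CC1CCN(c2c(S(=O)(=O)c3ccccc3)cnc3cc(F)ccc23)CC1`: 87%
Compound 3 `CC1CCN(c2c(S(=O)(=O)c3ccc(F)cc3)cnc3cc(F)ccc23)CC1`: 74.5%

In an assay on isolated protein for displacement of a labelled ligand from metabotropic glutamate receptor 5 (Homo sapiens), with a stated time of 60 min, tested at 1 uM (on this read-out higher numbers stand for more inhibition at the one concentration tested (going by the name of the read-out) and lower numbers for less inhibition), compound 3 gives the lowest of the three numbers. The gap is beyond the scatter to both neighbours: a number 12.5 percentage points lower from compound 2 to compound 3 (beyond the scatter) and a number 19.5 percentage points lower from compound 1 to compound 3 (beyond the scatter). Compound 4 `Cc1ccc(S(=O)(=O)c2cnc3cc(F)ccc3c2N2CCC(C)CC2)cc1` is not yet measured; it differs from compound 3 in one place, (methyl in place of fluoro on an aromatic carbon).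

Among the measured compounds shown here, two measured steps touch the same aromatic carbon. The step of a number 12.5 percentage points lower from compound 2 to compound 3 (beyond the scatter) shows that adding fluoro there lowered the number. The step of a number 7 percentage points lower from compound 1 to compound 2 (within the scatter), removing both chlorines, stayed within the scatter. For the measured compounds named here, no measured compound carries methyl at that position, so its effect is not known from these data. Since hydrogen gave a higher number than fluoro, a return toward the number of compound 2 seems plausible, but a methyl need not behave like either. Compound 4 is therefore expected to sit a little above compound 3, with a step of a number 7.5 percentage points higher from compound 3 to compound 4 (within the scatter) in this assay, estimated at 82% within 62% to 96%.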

Compound 4, a percentage reported as inhibition, at one concentration (the size of the read-out at that concentration, not a potency): 88%
Compound 4: the middle estimate sits 6 percentage points below what was measured; the measured number falls inside the stated range.
By their numbers in this assay, from the lowest: compound 3; then compounds 2, 4 and 1 (each within the scatter of the next).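

Compound 4 shows that this aromatic carbon can carry a substituent other than fluoro without the number falling in this assay, since the change from fluoro to methyl gives a number 13.5 percentage points higher from compound 3 to compound 4 (beyond the scatter) and so reverses the loss seen with fluoro. Methyl in place of hydrogen gives a number 1 percentage points higher from compound 2 to compound 4 (within the scatter) and thus leaves compounds 2 and 4 indistinguishable. The 4-methylphenyl and 3,4-dichlorophenyl groups also cannot be separated, with a number 6 percentage points lower from compound 1 to compound 4 (within the scatter) as the printed step, so among the four compounds only the 4-fluorophenyl of compound 3 stands apart.

From the compounds shown here alone, whether a methoxy group, an amine or a carboxylic acid on this carbon would keep the number up remains open. No measurement shown here accounts for the difference between fluoro and methyl at this carbon.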